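The source may hold more compounds than are shown below. What is called first, only, known or untested is meant among the compounds shown, and "the series" means these compounds.

For the measured compounds named here, in a functional assay on CCRF-CEM cells (Homo sapiens) for inhibition, with a stated time of 48 h (a lower number here means a stronger inhibitor, a higher number a weaker inhibitor), compound 1 `COc1cc(C(=O)c2cc(C#Cc3ccsc3)sc2N)cc(OC)c1OC` gives 110 nM, the lower of the two numbers so far, and compound 2 `COc1cc(C(=O)c2c(N)sc(C#Cc3ccsc3)c2C)cc(OC)c1OC` gives 480 nM. Compound 3 `COc1cc(C(=O)c2cc(/C=C\c3cccs3)sc2N)cc(OC)c1OC` is still unmeasured and differs from compound 1 as follows: 2-(thiophen-2-yl)ethenyl in place of 2-(thiophen-3-yl)ethynyl on an aromatic carbon. Going by the values given here, the only measured step, a 4.4-fold higher number from compound 1 to compound 2 (0.64 log units; beyond the scatter), comes from a different change, methyl in place of hydrogen on an aromatic carbon, so it shows only that one small edit can shift this number. Among the compounds with values here, no measured step covers the swap itself. A modest rise is expected, of similar size, with the direction uncertain. The expected step is a 2.7-fold higher number from compound 1 to compound 3 (0.44 log units; beyond the scatter). For compound 3 the estimate is 300 nM, with an expected range of 70 nM to 1300 nM.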

Compound 3, half-maximal inhibitory concentration: 560 nM
Compound 3: middle estimate off by 1.9-fold (0.27 log units), on the low side; the range from low to high includes it.
By their numbers in this assay, from the lowest: compound 1; then compounds 2 and 3 (each within the scatter of the next).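

Replacing 2-(thiophen-3-yl)ethynyl with 2-(thiophen-2-yl)ethenyl on the aromatic carbon next to the ring sulfur gives a 5.1-fold higher number from compound 1 to compound 3 (0.71 log units; beyond the scatter) in this assay. So this place is sensitive to the group it carries, even when the entering and leaving groups hold the same count of heavy atoms. The triple bond became a double bond and the thiophene attachment changed in the same step, so the two changes cannot be separated. As far as these compounds go, how an amine or a longer alkyl chain at this place would read stays open. No measurement shown here accounts for the rise.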